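A few compounds are considered here, and "the series" means these few. Any claim that something is new, unique, unknown or untested is made for them only; others in the source may bear on it.

Compound 1 `COc1ccc(-c2cc(/C=C/C(=O)c3ccc(N)cc3)[nH]n2)cc1`, compound 2 `COc1ccc(-c2cc(/C=C/C(=O)c3ccc(N)cc3)[nH]n2)cc1OC` and compound 3 `COc1ccc(-c2cc(/C=C/C(=O)c3cc(OC)c(OC)c(OC)c3)[nH]n2)cc1OC` were examined in a functional assay on MCF7 cells (Homo sapiens) for inhibition, read by MTT assay, with a stated time of 48 h; a lower number here means a stronger inhibitor, a higher number a weaker inhibitor. In this assay compound 1 gives 800 nM, compound 2 gives 1900 nM and compound 3 gives 1100 nM. Compound 2 and compound 1 differ by hydrogen in place of methoxy on an aromatic carbon, which made a step of a 2.4-fold lower number from compound 2 to compound 1 (0.38 log units; beyond the scatter). The difference between the cores of compound 3 and compound 2 is not broken down here. Compound 4 `COc1ccc(-c2cc(/C=C/C(=O)c3cc(OC)c(OC)c(OC)c3)[nH]n2)cc1` has not yet been measured; it differs from compound 3 by hydrogen in place of methoxy on an aromatic carbon, the same change seen earlier, which read one bond further out is 3,4-dimethoxyphenyl to 4-methoxyphenyl. The expected step is a 2.4-fold lower number from compound 3 to compound 4 (0.38 log units; beyond the scatter), because the same change gave a 2.4-fold lower number from compound 2 to compound 1 (0.38 log units; beyond the scatter). Compound 4 is therefore estimated at 460 nM, with a likely range from 250 nM to 900 nM.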

Compound 4, half-maximal inhibitory concentration: 2000 nM
Compound 4: the middle estimate sits 4.3-fold (0.64 log units) below what was measured; measured number outside the range, above it.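

On the core of compound 3, the change from 3,4-dimethoxyphenyl to 4-methoxyphenyl gave in this assay a 1.8-fold higher number from compound 3 to compound 4 (0.26 log units; within the scatter), and the step seen on the other core did not carry over: the same change on two cores in this assay, a 2.4-fold lower number (0.38 log units; beyond the scatter) from compound 2 to compound 1 and a 1.8-fold higher number (0.26 log units; within the scatter) from compound 3 to compound 4, 4.3-fold (0.64 log units) apart, beyond the scatter of two such steps. The size of this step therefore cannot be transferred as a fixed increment from one core to the other in this series. Two pairs do not show which feature of the cores sets the gap, and the new step alone cannot be told apart from no change at all.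

The compounds shown leave open how a hydroxyl, a fluorine or an ethoxy group would behave at this place on either core. They also leave open whether a third core would follow either pair.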